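The source may hold more compounds than are shown below. What is called first, only, known or untested is meant among the compounds shown, and "the series" means these compounds.

In a functional assay on MOLT-4 cells (Homo sapiens) for inhibition, read by MTT assay, with a stated time of 48 h (a higher number here means a weaker inhibitor, a lower number a stronger inhibitor), compound 2 `CC(C)CCn1cc(/C=C/C(=O)CC(=O)C(=O)O)c2ccccc21` gives 20000 nM and compound 3 `O=C(/C=C/c1cn(Cc2ccccc2)c2ccccc12)CC(=O)C(=O)O` gives 15000 nM. For compound 1 `CCOC(=O)C(=O)CC(=O)/C=C/c1cn(Cc2ccc(Cl)cc2)c2ccccc12`, the result reads "not determined" (no result reported). Compound 3 therefore has only compound 2 as a numerical neighbour, and the two values lie within the scatter of each other, so they cannot be ranked.

Compound 4 `O=C(/C=C/c1cn(Cc2ccc(Cl)cc2)c2ccccc12)CC(=O)C(=O)O` is compound 3 with chloro in place of hydrogen on an aromatic carbon, para to a large group, turning benzyl into 4-chlorobenzyl: chloro in place of hydrogen on an aromatic carbon. Compound 1 carries the same 4-chlorobenzyl group, but without a number it offers no guide to this change.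

Among the measured compounds shown here, the only measured step that bears on the question is a 1.3-fold lower number from compound 2 to compound 3 (0.12 log units; within the scatter). It changes the same side group, yet it does not test chloro itself, and the data hold no direct measure of that substitution. A step this small gives no reason to expect a large shift in this assay. The expected change is a 1.4-fold lower number from compound 3 to compound 4 (0.13 log units; within the scatter), a slight move towards a lower number that stays within the scatter. Compound 4 is estimated at 11000 nM, with an expected range from 5000 nM to 22000 nM.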

Compound 4, half-maximal inhibitory concentration: 19000 nM
For compound 4 the middle estimate is 1.7-fold (0.24 log units) below the measured one, within the range that was stated.
By their numbers in this assay, from the lowest: compounds 3, 4 and 2 (each within the scatter of the next).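

In this assay, among the compounds shown here, the step of a 1.3-fold higher number from compound 3 to compound 4 (0.10 log units; within the scatter) is the first direct reading of chloro in place of hydrogen on an aromatic carbon, para to a large group, and it shows that turning benzyl into 4-chlorobenzyl on this core gives no change that can be told from repeat measurements. The second new step, a 1.1-fold lower number from compound 2 to compound 4 (0.02 log units; within the scatter), likewise stays within the scatter, so the isobutyl-ending, benzyl and 4-chlorobenzyl side groups on the aromatic nitrogen cannot be ranked against one another in this set. No available evidence bears on this result.

Going by these compounds, whether a different group in the same place, such as methoxy, an amine or a carboxylic acid, would separate from these compounds in this assay remains open, as does whether a larger replacement for the whole benzyl group would do so. Also open, on these data alone, is the effect of an ethyl ester in place of the free acid, for compound 1, which pairs that ester with the same 4-chlorobenzyl group, reads "not determined" (no result reported).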